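This account rests on a few compounds, and the source may have more. Where it says the series, first, only, none or still open, it means among the compounds named here.

Measured in a functional assay on A549 cells (Homo sapiens) for inhibition, read by MTT assay; on this read-out higher numbers stand for weaker inhibition and lower numbers for stronger inhibition:

compound 1 `CCOC(=O)c1c(N)sc(C(=O)Nc2ccccc2)c1-c1ccccc1`: 6800 nM
compound 2 `CCOC(=O)c1c(NC(=O)CC#N)sc(C(=O)Nc2ccccc2)c1-c1ccccc1`: 320 nM
compound 3 `N#CCC(=O)Nc1sc(C(=O)Nc2ccccc2)c(-c2ccccc2)c1C#N`: 7590 nM

Compound 2 gives the lowest of the three numbers in this assay. The two steps that connect it to the others are both large and beyond the scatter: a 21-fold lower number from compound 1 to compound 2 (1.33 log units; beyond the scatter), where the (cyanomethyl)carbonyl group enters on the ring nitrogen, and a 24-fold higher number from compound 2 to compound 3 (1.38 log units; beyond the scatter), where the ethoxycarbonyl group is replaced by cyano. Both of these steps alter substituents on the shared core; neither touches the phenylcarbamoyl part.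

Compound 4 `CCOC(=O)c1c(NC(=O)CC#N)sc(C(=O)Nc2ccc(Cl)cc2)c1-c1ccccc1` differs from compound 2 only in that part: chloro in place of hydrogen on an aromatic carbon. Going by the values given here, no measured step in this set bears on such a change, since the phenylcarbamoyl group is the same in compound 1, compound 2 and compound 3. The core, with its ethoxycarbonyl and (cyanomethyl)carbonyl groups, is kept intact, and these are the groups whose removal or exchange produced the large steps above. Without any precedent for substitution on the anilide ring, a step of no more than the usual scatter is expected, in either direction, no change at the digits printed from compound 2 to compound 4 (within the scatter). Compound 4 is therefore estimated at 320 nM in this assay, with a range of 110 nM to 950 nM.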

Compound 4, half-maximal inhibitory concentration: 600 nM
Compound 4: middle estimate off by 1.9-fold (0.27 log units), on the low side; the range from low to high includes it.
By their numbers in this assay, from the lowest: compounds 2 and 4 (each within the scatter of the next); then compounds 1 and 3 (each within the scatter of the next).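

Working notes on the phenylcarbamoyl part: in this assay, chloro in place of hydrogen on an aromatic carbon, para to a large group, gives a 1.9-fold higher number from compound 2 to compound 4 (0.27 log units; within the scatter), the first measured change in this part of the series. The step lies within the scatter, so compound 2 and compound 4 cannot be told apart, whereas the two steps on the shared core, a 21-fold lower number from compound 1 to compound 2 (1.33 log units; beyond the scatter) and a 24-fold higher number from compound 2 to compound 3 (1.38 log units; beyond the scatter), both lie beyond it; in this one pair, a single chlorine at this place leaves the reading unresolved from that of the unsubstituted phenyl. No supporting measurement is available to account for this result.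

This single pair says nothing about whether an amine, a carboxylic acid or a methoxy group on the same carbon, or a longer chain in place of the whole phenyl, would also stay within the scatter. It also leaves open whether (4-chlorophenyl)carbamoyl would read the same way on the cyano core of compound 3, where the ethoxycarbonyl group is absent.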